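The source may hold more compounds than are shown below. What is called first, only, known or untested is meant among the compounds shown, and "the series" means these compounds.

Compound 1 `COc1ccc(CN(c2cc(OC)c(OC)c(OC)c2)S(=O)(=O)c2ccc(C)cc2)cc1` is the reference. In a functional assay on MGC-803 cells (Homo sapiens) for inhibition, read by MTT assay, with a stated time of 48 h (a lower number here means a stronger inhibitor, a higher number a weaker inhibitor), compound 1 gives 4340 nM. Compound 2 `COc1ccc(CN(c2cc(OC)c(OC)c(OC)c2)S(=O)(=O)c2ccccc2)cc1` carries hydrogen in place of methyl on an aromatic carbon. In this assay compound 2 reaches only a limit, > 50000 nM, and not a number, the limit being (the limit of > 50000 nM in this assay, at which 1 of the 3 values shown sits). That step, an at least 11-fold higher number from compound 1 to compound 2 (1.06 log units; beyond the scatter), is large. Compound 3 `COc1cc(N(Cc2cccc(C)c2)S(=O)(=O)c2ccc(C)cc2)cc(OC)c1OC` differs from compound 1 by 3-methylphenyl in place of 4-methoxyphenyl on a saturated chain carbon bound to a sulfonamide nitrogen. In this assay compound 3 gives 4340 nM, and the step of no change at the digits printed from compound 1 to compound 3 (within the scatter) shows no change. Compound 4 `COc1cc(N(Cc2ccccc2)S(=O)(=O)c2ccc(C)cc2)cc(OC)c1OC` is not yet measured; it differs from compound 3 by hydrogen in place of methyl on an aromatic carbon, the same kind of change as that from compound 1 to compound 2, yet here the place is meta to a large group rather than para to a large group, and on the benzyl ring rather than the sulfonyl ring. Because the step of no change at the digits printed from compound 1 to compound 3 (within the scatter) shows the benzyl ring tolerates a changed substituent, he expects a smaller step, a 1.8-fold higher number from compound 3 to compound 4 (0.27 log units; within the scatter), for compound 4. His estimate for compound 4 is 8000 nM, between 3000 nM and 30000 nM.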

Compound 4, half-maximal inhibitory concentration: 3570 nM
Compound 4: the middle estimate sits 2.2-fold (0.35 log units) above what was measured; low and high end bracket the measured number.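

In this assay, hydrogen in place of methyl on an aromatic carbon gives a 1.2-fold lower number from compound 3 to compound 4 (0.08 log units; within the scatter), and the same replacement made on a methoxy group gives a 1.2-fold lower number from compound 1 to compound 4 (0.08 log units; within the scatter). From the compounds shown here alone, the change to hydrogen in place of methyl therefore does not carry over from one core to the other: the same change on two cores in this assay, an at least 11-fold higher number (1.06 log units; beyond the scatter) from compound 1 to compound 2 and a 1.2-fold lower number (0.08 log units; within the scatter) from compound 3 to compound 4, at least 14-fold (1.14 log units) apart, beyond the scatter of two such steps Compound 2 gives only a limit, > 50000 nM, so the full size of its step stays unknown, and these two cores do not show why the steps differ or how the change would behave on any other core.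

The compounds shown leave open how an amine, a hydroxyl or a carboxylic acid in place of that methyl would read in this assay. They also leave open how a longer chain on the sulfonamide nitrogen would read there.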